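Toward Compound 4: a Methyl Replaces a Nitrile

A few compounds are considered here, and "the series" means these few. Any claim that something is new, unique, unknown or untested is made for them only; others in the source may bear on it.

Compound 1, `COc1ccc(-c2cnc(NC(=O)CCc3ccccc3)n2C)cc1`, in a toxicity assay on THP-1 cells (Homo sapiens) for inhibition (a lower number here means that less compound is tolerated, a higher number that more compound is tolerated), gives > 100000 nM, which is a limit of the assay and not a number.
Compound 2, `COc1ccc(-c2cnc(NC(=O)c3ccccc3Br)n2C)cc1`, in this assay gives > 100000 nM, again a limit.
Compound 3, `COc1ccc(-c2cnc(NC(=O)c3ccccc3C#N)n2C)cc1`, in this assay gives > 100000 nM, also a limit.

Compound 3 therefore stands at the same limit as the other two, (the limit of > 100000 nM in this assay, at which 3 of the 3 values shown sit). The steps a step that the two limits leave unreadable from compound 1 to compound 3 and a step that the two limits leave unreadable from compound 2 to compound 3 cannot be read, since both ends are limits. Compound 4, `COc1ccc(-c2cnc(NC(=O)c3cccc(C)c3)n2C)cc1`, differs from compound 3 by 3-methylphenyl in place of 2-cyanophenyl on a carbonyl carbon. Among the compounds with values here, none of the measured steps gives a readable size, so no direction can be drawn from them; the only pattern is that all three measured compounds sit at the limit. Compound 4 is expected at 100000 nM, with a range from 30000 nM to 300000 nM. The expected change is a number no higher from compound 3 to compound 4 (the limit leaves the size open), most likely ending again at the limit.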

Compound 4, half-maximal cytotoxic concentration: > 100000 nM
Compound 4 ended at the assay's limit (the forecaster's own chance of this, stated with the estimate: 80%); the middle value sits exactly at the limit.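

Compound 4, like compound 1, compound 2 and compound 3, gives only a limit, so no step among these four compounds can be read. Still open, as far as these compounds go, is whether these compounds differ at all in this assay once actual numbers replace the limit.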